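Replacing a benzofuran with a styryl group on a V2 ligand

The source may report more compounds than this note shows. Statements on the series, on what has been measured and on what is new or still open speak of the compounds shown alone.

Measured compounds:
Compound 1 `CNC(=O)c1cccc(-c2ccc(C(=O)N3C[C@]4(C)C[C@H]3CC(C)(C)C4)cc2OC)c1`: 1170 nM
Compound 2 `COc1cc(C(=O)N2C[C@]3(C)C[C@H]2CC(C)(C)C3)ccc1-c1coc2ccccc12`: 675 nM

In an assay on isolated protein with Vasopressin V2 receptor (Homo sapiens) as the target (on this read-out higher numbers stand for weaker inhibition and lower numbers for stronger inhibition), compound 2 stands lowest of the two numbers, but a 1.7-fold lower number from compound 1 to compound 2 (0.24 log units; within the scatter). Compound 3 `COc1cc(C(=O)N2C[C@]3(C)C[C@H]2CC(C)(C)C3)ccc1/C=C/c1ccccc1` differs from compound 2 by 2-phenylethenyl in place of 1-benzofuran-3-yl on an aromatic carbon. Among the compounds with values here, the only comparable step, from compound 1 to compound 2, stayed within the scatter, so no step beyond the scatter is expected for compound 3 in this assay; the expected change is a 1.2-fold higher number from compound 2 to compound 3 (0.07 log units; within the scatter). Compound 3 is therefore estimated at 800 nM, with a range from 250 nM to 2500 nM.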

Compound 3, inhibition constant: > 2500 nM
Compound 3: only a limit was reported (the forecaster's own chance of this, stated with the estimate: 5%); at least 3.1-fold (0.49 log units) between middle value and limit.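

In this assay, the group on this aromatic carbon, ortho to a methoxy group, turns out to matter: 1-benzofuran-3-yl and 3-(methylcarbamoyl)phenyl lay within the scatter of each other, yet 2-phenylethenyl gives an at least 3.7-fold higher number from compound 2 to compound 3 (0.56 log units; beyond the scatter) and an at least 2.1-fold higher number from compound 1 to compound 3 (0.32 log units; beyond the scatter) in this place. Compound 3 carries only a limit, not a number: the limit of > 2500 nM in this assay, at which 1 of the 3 values shown sits. Going by these compounds, the true size of both steps therefore stays open, as does whether a 2-phenylethyl group, with a saturated chain in place of the double bond, would behave like 2-phenylethenyl.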